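From chloro to methyl on an aromatic carbon

The source may report more compounds than this note shows. Statements on the series, on what has been measured and on what is new or still open speak of the compounds shown alone.

In a functional assay on MCF7 cells (Homo sapiens) for antiproliferative activity, read by colorimetric assay and MTT assay, with a stated time of 48 h (a higher number here means a weaker inhibitor, a lower number a stronger inhibitor), compound 1 (`O=C(NS(=O)(=O)c1ccc(F)cc1)c1ccncc1`) gives 13900 nM and compound 2 (`O=C(NS(=O)(=O)c1ccc(Cl)cc1)c1ccncc1`) gives 10100 nM on the same read-out. These two values lie within the scatter of each other, so compound 2 stands level with compound 1 and is not separated from it.

Compound 3 (`Cc1ccc(S(=O)(=O)NC(=O)c2ccncc2)cc1`) has no number yet. Its difference from compound 2 (methyl in place of chloro on an aromatic carbon) is methyl in place of chloro on an aromatic carbon, para to a large group.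

Among the compounds with values here, only one measured step bears on this change: chloro in place of fluoro on an aromatic carbon (a 1.4-fold lower number from compound 1 to compound 2 (0.14 log units; within the scatter)). That step stays within the scatter. Within the data shown here, it is limited guidance, as it involves two halogens and no methyl compound has been measured. No step beyond the scatter is therefore expected in this assay, and neither direction is favoured. The expected step is small (a 1.2-fold higher number from compound 2 to compound 3 (0.07 log units; within the scatter)). Compound 3 is expected at 12000 nM (estimated range 6000 nM to 25000 nM).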

Compound 3, half-maximal inhibitory concentration: 14100 nM
Compound 3: the middle estimate sits 1.2-fold (0.07 log units) below what was measured; the range from low to high includes it.
By their numbers in this assay, from the lowest: compounds 2, 1 and 3 (each within the scatter of the next).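

In this assay, methyl at this position, on an aromatic carbon para to a large group, reads much like either halogen: replacing chloro gives the step (a 1.4-fold higher number from compound 2 to compound 3 (0.14 log units; within the scatter)), and replacing fluoro gives the step (a 1.0-fold higher number from compound 1 to compound 3 (0.01 log units; within the scatter)). The earlier pair held only two halogens, so it could not show that a carbon group on this aromatic carbon also stays within the scatter of both, and fluoro, chloro and methyl are now not separated from one another in this assay. Nothing in the available data accounts for this lack of separation.

From the compounds shown here alone, these three groups each bring a single heavy atom, so it remains open whether a larger or differently built group at this position, such as an amine, a carboxylic acid, a methoxy group or a longer chain, would move the number beyond the scatter. Also open, going by these compounds, is whether any change elsewhere on the shared core would separate compounds in a way that these three single-atom swaps do not.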